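The source may report more compounds than this note shows. Statements on the series, on what has been measured and on what is new or still open speak of the compounds shown alone.

Measured so far:
- compound 1 `C/C(C#Cc1ccccc1)=N\N/C(N)=N/S(=O)(=O)c1cc(C)c(Cl)cc1SCc1ccccc1C`: 150000 nM
- compound 2 `Cc1cc(S(=O)(=O)/N=C(\N)N/N=C/C#Cc2ccccc2)c(SCc2cccc3ccccc23)cc1Cl`: 22000 nM

In a functional assay on MCF7 cells (Homo sapiens) for antiproliferative activity, read by MTT assay, with a stated time of 72 h (on this read-out lower numbers stand for stronger inhibition and higher numbers for weaker inhibition), compound 1 gives 150000 nM. Compound 2 gives 22000 nM in this assay, the lower of the two numbers, and the gap to compound 1 lies beyond the scatter. Among the compounds with values here, compound 1 and compound 2 differ in two places at once, so no single step between measured compounds can be read from them.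

Compound 3 `C/C(C#Cc1ccccc1)=N\N/C(N)=N/S(=O)(=O)c1cc(C)c(Cl)cc1SCc1cccc2ccccc12` has not been measured. It keeps the thioether substituent of compound 2 and differs from it by a group of 11 heavy atoms (10 carbon, 1 nitrogen; one six-membered aromatic ring of carbon only) in place of a group of 10 heavy atoms (9 carbon, 1 nitrogen; one six-membered aromatic ring of carbon only), on an amine nitrogen. Compound 1 carries this same group on the amine nitrogen, together with its own thioether substituent, so the pair compound 1 and compound 2 gives only a loose hint. The step from compound 2 to compound 3 is expected to be small to moderate, towards a higher number, roughly a 2.0-fold higher number from compound 2 to compound 3 (0.31 log units; beyond the scatter). Compound 3 is thus expected at 45000 nM, within 15000 nM to 140000 nM.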

Compound 3, half-maximal inhibitory concentration: 210000 nM
Beside the measured number, compound 3's estimate is 4.7-fold (0.67 log units) below it; the measured number lies above the stated range.
By their numbers in this assay, from the lowest: compound 2; then compounds 1 and 3 (each within the scatter of the next).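

In this assay, with naphthalen-1-yl kept on the thioether, the group of 11 heavy atoms in place of the group of 10 heavy atoms on an amine nitrogen gives a 9.5-fold higher number from compound 2 to compound 3 (0.98 log units; beyond the scatter), so this position now has a step of its own that lies beyond the scatter. With the group on the amine nitrogen held constant, naphthalen-1-yl in place of 2-methylphenyl on a saturated chain carbon bound to a sulfur gives a 1.4-fold higher number from compound 1 to compound 3 (0.15 log units; within the scatter), a step within the scatter. No measurement in hand accounts for either step.

On these data alone, whether the step at the amine nitrogen also holds with 2-methylphenyl on the thioether remains open. Also open, as far as these compounds go, is how a group bearing an ethyl chain or a carboxylic acid would read at that amine nitrogen.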